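Pyridyl methylsulfonyl variant in a piperidine carbamate series

This account rests on a few compounds, and the source may have more. Where it says the series, first, only, none or still open, it means among the compounds named here.

Measured in a functional assay on CHO-K1 cells with Glucose-dependent insulinotropic receptor (Homo sapiens) as the target, read by a luciferase reporter, with a stated time of 5 h; on this read-out higher numbers stand for larger maximal responses and lower numbers for smaller maximal responses:
compound 1 `CC(C)OC(=O)N1CCC(Oc2ncnc3c2CCN3c2ccc(S(C)(=O)=O)cc2)CC1` — 154%
compound 2 `CC(C)OC(=O)N1CCC(Oc2ncnc3c2CCN3c2ccc(C#N)cc2F)CC1` — 134%
compound 3 `CC(C)OC(=O)N1CCC(Oc2ncnc3c2CCN3c2ccc(-c3cccn3C)cc2F)CC1` — 44%

Compound 2 stands second highest of the three: compound 1 lies above it and compound 3 far below it, both gaps beyond the scatter. The unmeasured compound 4 `CC(C)OC(=O)N1CCC(Oc2ncnc3c2CCN3c2ccc(S(C)(=O)=O)nc2)CC1` differs from compound 2 in one place: 6-(methylsulfonyl)pyridin-3-yl in place of 4-cyano-2-fluorophenyl on a nitrogen on an aromatic ring in a ring. Within the data shown here, one measured step bears on this, running the opposite way, from a methylsulfonyl-bearing ring to the cyano-fluorophenyl: a number 20 percentage points lower from compound 1 to compound 2 (beyond the scatter). The other step, a number 90 percentage points lower from compound 2 to compound 3 (beyond the scatter), concerns a different change and gives no guidance. Among the measured compounds shown here, the ring nitrogen of 6-(methylsulfonyl)pyridin-3-yl is sampled by no measured step. A modest upward step is therefore expected in this assay. Compound 4 is estimated at 148%, within 125% to 170%, an expected a number 14 percentage points higher from compound 2 to compound 4 (beyond the scatter).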

Compound 4, largest response reached (reported as percent of maximum), in percent of the reference or control that the assay uses: 97%
The estimate for compound 4 lay 51 percentage points above the measured number; measured number below the stated range.
By their numbers in this assay, from the lowest: compound 3; then compound 4; then compound 2; then compound 1.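

In this assay, putting a hetero atom into the aromatic ring while keeping the methylsulfonyl group cost much of the response, with a number 57 percentage points lower from compound 1 to compound 4 (beyond the scatter). The methylsulfonyl group therefore does not by itself secure a high maximal response at this position, since the change from the cyano-bearing ring also gave a number 37 percentage points lower from compound 2 to compound 4 (beyond the scatter). Nothing available here accounts for this loss. As far as these compounds go, how an ethylsulfonyl group or an amine in place of methylsulfonyl on the same ring would behave remains open.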